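This account rests on a few compounds, and the source may have more. Where it says the series, first, only, none or still open, it means among the compounds named here.

Compound 2 `Cn1nnc(-c2c(F)cc(Cl)cc2-c2cnc(CNC(=O)N(O)C(C)(C)C)c(F)c2)n1` gives the lowest number seen so far in a functional assay on IMR-90 cells for antagonist activity at B1 bradykinin receptor (Homo sapiens), read by calcium flux (a lower number here means a stronger inhibitor, a higher number a weaker inhibitor), namely 1.4 nM. Going by the values given here, its only measured neighbour is compound 1 `CN(O)C(=O)NCc1ncc(-c2cc(Cl)cc(F)c2-c2nnn(C)n2)cc1F`, which in this assay gives 17 nM; the two differ in a single place, and the step of a 12-fold lower number from compound 1 to compound 2 (1.08 log units; beyond the scatter) shows that exchanging a methyl for a tert-butyl on the amide-type nitrogen moved the number a long way down.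

Compound 3 `Cn1nnc(-c2c(F)cc(Cl)cc2-c2cnc(CNC(=O)N(O)C3CCCC3)c(F)c2)n1` carries a further change at that same place: cyclopentyl in place of tert-butyl on an amide-type nitrogen. Among the compounds with values here, no measured pair shows exactly this exchange. Within the data shown here, the only step that bears on it, a 12-fold lower number from compound 1 to compound 2 (1.08 log units; beyond the scatter), concerns a different pair of groups and a much larger jump in the count of heavy atoms, so it is a loose guide at best. With a carbon-only group of nearly the same count staying in place, the expectation is a step of a 1.1-fold higher number from compound 2 to compound 3 (0.03 log units; within the scatter), that is, nothing beyond the scatter in either direction.

Compound 3 is therefore estimated at 1.5 nM in this assay, with a likely range from 0.5 nM to 5 nM.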

Compound 3, half-maximal inhibitory concentration: 0.8 nM
Estimate against measurement, compound 3: 1.9-fold (0.27 log units) above; low and high end bracket the measured number.
By their numbers in this assay, from the lowest: compounds 3 and 2 (each within the scatter of the next); then compound 1.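

In this assay, going by these compounds alone, the tert-butyl group of compound 2 turns out not to be the only group that works at this position. The step of a 1.8-fold lower number from compound 2 to compound 3 (0.24 log units; within the scatter) stays within the scatter, so on this amide-type nitrogen a closed ring of carbon, cyclopentyl, and an open branched carbon group cannot be told apart. The step of a 21-fold lower number from compound 1 to compound 3 (1.33 log units; beyond the scatter) lies beyond the scatter and is large, like a 12-fold lower number from compound 1 to compound 2 (1.08 log units; beyond the scatter) before it, so in the three compounds shown both of the bigger carbon groups give a far lower number than methyl, with no compound going against this; no measurement at hand explains why.

The compounds shown leave open where between methyl and these larger groups the number falls, which ethyl, isopropyl or cyclopropyl on the same nitrogen would help to settle. They also leave open whether the position needs carbon alone, a question that a tetrahydropyranyl ring or a chain ending in an amine or a carboxylic acid would address.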